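The compounds below may be only part of what the source reports. "The series", "measured", "known", "first", "only" and "open" are said of these compounds alone.

Going by the values given here, in a functional assay with Oryctolagus cuniculus as the target (on this read-out higher numbers stand for weaker inhibition and lower numbers for stronger inhibition), compound 2 `CCOC(=O)/C=C/c1nc(-c2ccc(OC)cc2)c(-c2ccc(OC)cc2)s1` gives 20 nM, the only actual number so far. Compound 1 `COc1ccc(-c2nc(/N=C(\N)NC(C)C)sc2-c2ccc(OC)cc2)cc1` stands at > 100 nM, which is a limit and not a number. Among the compounds with values here, the one measured step, an at least 5.0-fold lower number from compound 1 to compound 2 (0.69 log units; beyond the scatter), exchanges a different group, so it bears only loosely on the present change. Compound 3 `COc1ccc(-c2nc(/C=C/C(=O)N3CCN(C)CC3)sc2-c2ccc(OC)cc2)cc1` differs from compound 2 by 4-methylpiperazin-1-yl in place of ethoxy on a carbonyl carbon, with 4-methylpiperazin-1-yl in place of ethoxy on a carbonyl carbon. Within the data shown here, no measured step covers this exchange, so only a modest move to a higher number in this assay is expected, starting from compound 2 at 20 nM. The expected size is a 2.5-fold higher number from compound 2 to compound 3 (0.40 log units; beyond the scatter). The estimate for compound 3 is 50 nM, within a range of 10 nM to 250 nM.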

Compound 3, half-maximal inhibitory concentration: > 1000 nM
Compound 3 gave a limit, no number; the forecaster's own chance of this, stated with the estimate: 35%; middle value at least 20-fold (1.30 log units) from the limit.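

In this assay, 4-methylpiperazin-1-yl in place of ethoxy on a carbonyl carbon gives an at least 50-fold higher number from compound 2 to compound 3 (1.69 log units; beyond the scatter), a large move towards weaker inhibition. The earlier step exchanged a whole group on an aromatic carbon, whereas this one shows that the group on the carbonyl carbon alone, with the chain kept, can decide the read-out. Compound 3 gives a limit and not a number: the limit of > 1000 nM in this assay, at which 1 of the 3 values shown sits.

The compounds shown leave open whether the loss goes with any amide on this carbonyl carbon or with the 4-methylpiperazin-1-yl group itself. A primary amide, a morpholine amide or the free carboxylic acid at this place would separate the two.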